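From benzyl to 4-chlorobenzyl: an expected cytotoxicity value

A few compounds are considered here, and "the series" means these few. Any claim that something is new, unique, unknown or untested is made for them only; others in the source may bear on it.

Measured in an ADME assay on A549 cells (Homo sapiens) for cytotoxicity, read by resazurin assay, with a stated time of 48 h; on this read-out lower numbers stand for higher toxicity in this test and higher numbers for lower toxicity in this test
Compound 1 `CCCNc1ccc(NC(=O)c2cc(Cl)ccc2O)c(Cl)c1` gives 22500 nM
Compound 2 `O=C(Nc1ccc(NCc2ccccc2)cc1Cl)c1cc(Cl)ccc1O` gives 19700 nM

Compound 2 gives 19700 nM and so lies within the scatter of compound 1 at 22500 nM with no other measured value to place it against. Compound 3 `O=C(Nc1ccc(NCc2ccc(Cl)cc2)cc1Cl)c1cc(Cl)ccc1O` carries chloro in place of hydrogen on an aromatic carbon, para to a large group, which turns benzyl into 4-chlorobenzyl (chloro in place of hydrogen on an aromatic carbon). Going by the values given here, the only measured step is (a 1.1-fold lower number from compound 1 to compound 2 (0.06 log units; within the scatter)) and it put phenyl in place of ethyl, so it bears on this change only indirectly. Among the compounds with values here, no measured step adds chloro to a ring. In this assay no step beyond the scatter is therefore expected, with any drift more likely toward a lower number. The expected change is a 1.3-fold lower number from compound 2 to compound 3 (0.12 log units; within the scatter) and it remains an estimate. Compound 3 is estimated at 15000 nM (expected range 6500 nM to 30000 nM).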

Compound 3, half-maximal cytotoxic concentration: 59700 nM
Beside the measured number, compound 3's estimate is 4.0-fold (0.60 log units) below it; the measured number lies above the stated range.
By their numbers in this assay, from the lowest: compounds 2 and 1 (each within the scatter of the next); then compound 3.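

In this assay, going by these compounds alone, chloro in place of hydrogen on an aromatic carbon, para to a large group, is the first change here to move the number beyond the scatter: a 3.0-fold higher number from compound 2 to compound 3 (0.48 log units; beyond the scatter), a modest shift toward lower toxicity in this test. Phenyl in place of ethyl had left the number within the scatter, so this position on the added ring responds where the ring alone showed no change, and 4-chlorophenyl in place of ethyl gives a 2.7-fold higher number from compound 1 to compound 3 (0.42 log units; beyond the scatter). Nothing available here accounts for this shift.

As far as these compounds go, whether the rise is particular to chloro remains open, since a fluoro, methyl or methoxy group at this position would be needed to tell. It is also unknown whether chloro on another carbon of this ring would give a similar step.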